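From tellurium to selenium in compound 4

The source may report more compounds than this note shows. Statements on the series, on what has been measured and on what is new or still open speak of the compounds shown alone.

Values in a functional assay on RAW264.7 cells (Mus musculus) for cytotoxicity, read by MTT assay, with a stated time of 24 h; on this read-out higher numbers stand for weaker inhibition and lower numbers for stronger inhibition:
- Compound 1 `O=S(=O)(O)OCCCCCCCCCC[Se]c1ccccc1`: > 100000 nM (a limit, not a number)
- Compound 2 `O=S(=O)(O)OCCCCCCCCCC[Te]c1ccccc1`: 5320 nM
- Compound 3 `O=S(=O)(O)OCCCCCCCCCCCC[Te]c1ccccc1`: 4960 nM

Compound 3 lies within the scatter of compound 2, so the two cannot be told apart in this assay. Compound 4 `O=S(=O)(O)OCCCCCCCCCCCC[Se]c1ccccc1` differs from compound 3 in one place: a group of 7 heavy atoms (6 carbon, 1 selenium; one six-membered aromatic ring of carbon only) in place of a group of 7 heavy atoms (6 carbon, 1 tellurium; one six-membered aromatic ring of carbon only), on a saturated chain carbon, ten or more bonds along the chain from an oxygen. For the measured compounds named here, the closest precedent is the same exchange in the opposite direction, an at least 18-fold lower number from compound 1 to compound 2 (1.27 log units; beyond the scatter). The chain change mattered little, a 1.1-fold lower number from compound 2 to compound 3 (0.03 log units; within the scatter). A large rise in the number is therefore expected, an 18-fold higher number from compound 3 to compound 4 (1.26 log units; beyond the scatter). For compound 4 the estimate is 90000 nM, within an expected range of 30000 nM to 200000 nM. The assay may well report only a limit, as in the limit of > 100000 nM in this assay, at which 1 of the 3 values shown sits.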

Compound 4, half-maximal inhibitory concentration: > 100000 nM
Compound 4 gave a limit, no number (the forecaster's own chance of this, stated with the estimate: 60%); middle value at least 1.1-fold (0.04 log units) away from the limit.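

Exchanging tellurium for selenium on the longer chain gives an at least 20-fold higher number from compound 3 to compound 4 (1.30 log units; beyond the scatter) in this assay. The large gap between the two elements therefore appears on both chains, not just the shorter one: the same change on two cores in this assay, an at least 18-fold lower number (1.27 log units; beyond the scatter) from compound 1 to compound 2 and an at least 20-fold lower number (1.30 log units; beyond the scatter) from compound 4 to compound 3; the limit leaves it open whether they differ The step between compound 1 and compound 4 cannot be read, as both values are limits.

Going by these compounds, how far the two selenium compounds lie beyond that limit stays open, so the full size of the exchange is unknown. Also open, on these data alone, is whether the tellurium compounds would keep their cytotoxicity with a carboxylic acid in place of sulfooxy.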